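The compounds below may be only part of what the source reports. "The series", "measured", "known", "first", "only" and "open" are said of these compounds alone.

Compound 1 `O=[N+]([O-])c1ccc(Oc2ccc(/C=N/NC(=S)Nc3ccc(Br)cc3)cc2)cc1` is the more lipophilic of the two measured compounds in a physicochemical assay for lipophilicity, in phosphate buffer, measured as octanol-water partition, with a stated time of 24 h; a higher number here means a more lipophilic compound, a lower number a more polar compound: compound 1 gives 5.68, while compound 2 `O=[N+]([O-])c1ccc(Oc2ccc(/C=N/NC(=S)Nc3ccccc3)cc2)cc1` gives 4.95. Among the measured compounds shown here, the only measured step, a number 0.73 log units lower from compound 1 to compound 2 (beyond the scatter), removes a bromo group and puts hydrogen in its place, and it moved the reading down by a modest amount.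

Compound 3 `Cc1ccc(Oc2ccc(/C=N/NC(=S)Nc3ccc(Br)cc3)cc2)cc1` differs from compound 1 in another place: methyl in place of nitro on an aromatic carbon. For the measured compounds named here, no measured step touches this part of the shared core, so the measured change from compound 1 to compound 2 does not bear directly on it; it shows only that a single change on an outer ring of this core can shift the reading beyond the scatter.

From compound 1 the reading of compound 3 in this assay is expected to move a number 0.72 log units higher from compound 1 to compound 3 (beyond the scatter), that is, upward. For compound 3 the estimated value in this assay is therefore 6.4, with a range from 5.8 to 7, an expectation that rests on a single compound and on the counted difference alone.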

Compound 3, partition coefficient: 6.17
Compound 3: the middle estimate sits 0.23 log units above what was measured; the measured number falls inside the stated range.
By their numbers in this assay, from the lowest: compound 2; then compound 1; then compound 3.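

In this assay, the swap from 4-nitrophenyl to 4-methylphenyl gives a number 0.49 log units higher from compound 1 to compound 3 (beyond the scatter), so this end of the shared core also affects the reading, which the step on the bromo-bearing ring could not show. The swap removes a group counted with 3 heavy atoms and 2 hydrogen-bond acceptors and puts in one counted with 1 heavy atom and no acceptors, and the reading goes up, whereas the step of a number 0.73 log units lower from compound 1 to compound 2 (beyond the scatter) goes down; both steps are printed as modest and beyond the scatter. Nothing available explains why this swap raises the number.

The compounds shown leave open how other groups on this aromatic carbon would read, such as an amine, a carboxylic acid or a longer chain like propyl, and a single swap at this place gives no trend across groups. From the compounds shown here alone, they also leave open whether the same swap would give a similar step on compound 2, which carries hydrogen in place of bromo, so it is unknown whether the two changes add up.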